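The compounds below may be only part of what the source reports. "The series", "measured", "known", "first", "only" and "open" are said of these compounds alone.

Measured in a toxicity assay on Hepa-1c1c7 cells (Mus musculus) for inhibition; on this read-out higher numbers stand for weaker inhibition and lower numbers for stronger inhibition:
- Compound 1 `CCCC(O)C#CC#CCO`: > 50000 nM (a limit).
- Compound 2 `CCCCCC(O)C#CC#CC(O)CCC`: 19000 nM.
- Compound 3 `CCCCC[C@@H](O)C#CC#CCO`: > 100000 nM (a limit).

Compound 3 stands at the limit of > 100000 nM in this assay, at which 1 of the 3 values shown sits, so it has no exact number. Compound 4 `CCCCCC(O)C#CC#CCO` changes only the drawing of the stereocentre: the two compounds have the same atoms and bonds; at least one stereo element is drawn with a configuration in one of them and without one in the other: 1 of 1 stereo elements differ; a stereocentre at a saturated chain carbon is drawn R in compound 3 and without a configuration in compound 4. Among the measured compounds shown here, the only measured step is an at least 2.6-fold lower number from compound 1 to compound 2 (0.42 log units; beyond the scatter). It adds a pentyl group and leaves configuration untested, so it bears only indirectly. For the measured compounds named here, no measured pair isolates a stereocentre, so no shift beyond the scatter is expected in this assay. The expected step is an at least 1.2-fold lower number from compound 3 to compound 4 (0.09 log units; that floor lies within the scatter). For compound 4 the estimate is 80000 nM, with an expected range of 30000 nM to 200000 nM.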

Compound 4, half-maximal inhibitory concentration: > 50000 nM
Compound 4: a limit, no number (the forecaster's own chance of this, stated with the estimate: 60%); the middle value is on the limit's open side.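

In this assay compound 4 gives > 50000 nM, which is a limit. Hydrogen in place of propyl gives an at least 2.6-fold higher number from compound 2 to compound 4 (0.42 log units; beyond the scatter), so this change matches an at least 2.6-fold lower number from compound 1 to compound 2 (0.42 log units; beyond the scatter): compound 2 is the only compound here with an exact number, and losing either its propyl or its pentyl leaves a limit. The steps to compound 4 from compound 3 and from compound 1 cannot be read, as each joins two limits.

As far as these compounds go, whether the configuration at the stereocentre matters stays open. So does the effect of a longer chain in place of pentyl, or of an amine in place of a hydroxyl.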